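The source may hold more compounds than are shown below. What is called first, only, known or untested is meant among the compounds shown, and "the series" means these compounds.

Compound 3 `NC(=O)c1c(NC(=O)c2ccccc2I)sc2c1CCN(C(=S)Nc1ccccc1C(F)(F)F)C2` gives 14200 nM in a functional assay on MKN-74 cells (Homo sapiens) for antiproliferative activity, with a stated time of 24 h (on this read-out higher numbers stand for weaker inhibition and lower numbers for stronger inhibition), and stands second highest of the three numbers. Nearest is compound 2 `NC(=O)c1c(NC(=O)c2ccccc2Br)sc2c1CCN(C(=S)Nc1ccccc1C(F)(F)F)C2` with 24300 nM, a step within the scatter, a 1.7-fold lower number from compound 2 to compound 3 (0.23 log units; within the scatter). Furthest is compound 1 `NC(=O)c1c(NC(=O)c2ccccc2Cl)sc2c1CCN(C(=S)Nc1ccccc1C(F)(F)F)C2` with 1870 nM, a 7.6-fold higher number from compound 1 to compound 3 (0.88 log units; beyond the scatter). Compound 4 `Cc1ccccc1C(=O)Nc1sc2c(c1C(N)=O)CCN(C(=S)Nc1ccccc1C(F)(F)F)C2` differs from compound 3 by methyl in place of iodo on an aromatic carbon. Within the data shown here, no measured step exchanges a halogen for methyl, so the halogen steps bear only loosely: a 13-fold higher number from compound 1 to compound 2 (1.11 log units; beyond the scatter) and a 7.6-fold higher number from compound 1 to compound 3 (0.88 log units; beyond the scatter) were both beyond the scatter, whereas the bromo-to-iodo step was not. A lower number is expected for compound 4, with wide uncertainty, a 3.2-fold lower number from compound 3 to compound 4 (0.50 log units; beyond the scatter). Compound 4 is estimated at 4500 nM, range 1000 nM to 20000 nM.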

Compound 4, half-maximal inhibitory concentration: 17400 nM
The estimate for compound 4 lay 3.9-fold (0.59 log units) below the measured number, and the stated range covers the measured number.
By their numbers in this assay, from the lowest: compound 1; then compounds 3, 4 and 2 (each within the scatter of the next).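

In this assay methyl in place of iodo gives a 1.2-fold higher number from compound 3 to compound 4 (0.09 log units; within the scatter) and methyl in place of bromo gives a 1.4-fold lower number from compound 2 to compound 4 (0.15 log units; within the scatter) so a non-halogen group at this place reads the same as these two heavier halogens. Only chloro stands apart, with a 9.3-fold higher number from compound 1 to compound 4 (0.97 log units; beyond the scatter) as the step to methyl, so among these four groups the low number belongs to chloro and not to halogens as a class, with compounds 2 and 3 going against the latter. Nothing available accounts for this separation. Still open, on these data alone, is whether fluoro, methoxy or an amine on this aromatic carbon would group with compound 1 or with compounds 2, 3 and 4.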